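This account rests on a few compounds, and the source may have more. Where it says the series, first, only, none or still open, it means among the compounds named here.

In a functional assay on HCT-116 cells (Homo sapiens) for inhibition, read by MTT assay, with a stated time of 72 h (on this read-out higher numbers stand for weaker inhibition and lower numbers for stronger inhibition), compound 2 `COc1ccc(CCCNCc2c(OC)cc(Oc3cccc(Nc4ccccc4)c3)cc2OC)cc1` gives 2850 nM. Compound 1 `COc1cc(Oc2cccc(Nc3ccccc3)c2)cc(OC)c1CNCc1ccc(F)cc1` gives 4220 nM in the same assay. The two numbers lie close together: a 1.5-fold lower number from compound 1 to compound 2 (0.17 log units; within the scatter), so on these data compound 2 and compound 1 stand on a level with each other. Compound 3 `CCN1CCN(Cc2c(OC)cc(Oc3cccc(Nc4ccccc4)c3)cc2OC)CC1` has not yet been measured in this assay. It differs from compound 2 in one place: 4-ethylpiperazin-1-yl in place of (3-(4-methoxyphenyl)propyl)amino on a saturated chain carbon bound to an aromatic carbon. Going by the values given here, the only measured step that touches the same part of the molecule is the one from compound 1 to compound 2, which also exchanged the group on the amine nitrogen and moved the number little: a 1.5-fold lower number from compound 1 to compound 2 (0.17 log units; within the scatter). Among the compounds with values here, that exchange kept a hydrogen-bond donor on the nitrogen; the step to compound 3 removes the donor and brings in a non-aromatic ring, a change of a different kind with no close precedent among the measured compounds. With only a small, within-scatter step to lean on, the expected change from compound 2 to compound 3 is a 1.4-fold higher number from compound 2 to compound 3 (0.15 log units; within the scatter), with no confident direction. Compound 3 is therefore estimated at 4000 nM in this assay, within a range from 1500 nM to 12000 nM.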

Compound 3, half-maximal inhibitory concentration: > 20000 nM
Compound 3 gave a limit, no number (the forecaster's own chance of this, stated with the estimate: 5%); middle value at least 5.0-fold (0.69 log units) from the limit.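

Until now, the position had been probed only with (4-fluorobenzyl)amino in compound 1 and (3-(4-methoxyphenyl)propyl)amino in compound 2, whose values lie within the scatter of each other, so it could have seemed to accept quite different groups. The new result shows that this tolerance does not extend to every group on the saturated chain carbon bound to an aromatic carbon: 4-ethylpiperazin-1-yl gives an at least 7.0-fold higher number from compound 2 to compound 3 (0.84 log units; beyond the scatter), and likewise an at least 4.7-fold higher number from compound 1 to compound 3 (0.67 log units; beyond the scatter). For compound 3, the result in this assay is a limit and not a number, so these steps fix only the smallest possible size of the loss: the limit of > 20000 nM in this assay, at which 1 of the 3 values shown sits.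

The change to compound 3 removes a hydrogen-bond donor and a six-membered aromatic ring of carbon only, and it adds a six-membered non-aromatic ring, so the compounds shown cannot tell which of these differences matters. An ethylamino group, which keeps the amine hydrogen but has no aromatic ring, and a 4-benzylpiperazin-1-yl group, which keeps an aromatic ring but has no amine hydrogen, would help pull these differences apart.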